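Trading a Second Hydroxyl for an Ethyl Branch

The source may hold more compounds than are shown below. What is called first, only, known or untested is meant among the compounds shown, and "the series" means these compounds.

Measured in a functional assay on HT cells (Homo sapiens) for antiproliferative activity, read by fluorescence, with a stated time of 72 h; on this read-out higher numbers stand for weaker inhibition of growth and lower numbers for stronger inhibition of growth:
- compound 1, `CC(C)c1n[nH]c2c(NCc3ccc(-c4ccccn4)cc3)nc(SCCNC(=N)N)nc12`, gives 390 nM
- compound 2, `CC(C)c1n[nH]c2c(NCc3ccc(-c4ccccn4)cc3)nc(SCC(O)CO)nc12`, gives 21 nM
- compound 3, `CNCCSc1nc(NCc2ccc(-c3ccccn3)cc2)c2[nH]nc(C(C)C)c2n1`, gives 56 nM

Among these three, compound 2 stands at the lowest number, with compound 3 the nearest and compound 1 the furthest away. The unmeasured compound 4, `CCC(CO)Sc1nc(NCc2ccc(-c3ccccn3)cc2)c2[nH]nc(C(C)C)c2n1`, differs from compound 2 only at the group attached to the sulfur: 1-(hydroxymethyl)propyl in place of 2,3-dihydroxypropyl on a sulfur. The new group keeps one hydroxyl and adds a carbon branch.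

Two measured steps change the same group on the same sulfur. The step of a 19-fold lower number from compound 1 to compound 2 (1.27 log units; beyond the scatter) shows that the group there can move the number a great deal, and the step of a 2.7-fold higher number from compound 2 to compound 3 (0.43 log units; beyond the scatter) shows that leaving the dihydroxyethyl arrangement costs a modest amount. Neither step removes just one hydroxyl, so the direction for compound 4 is uncertain, though a modest rise in the number seems more likely than a fall.

For compound 4 the expected step is a 2.1-fold higher number from compound 2 to compound 4 (0.33 log units; beyond the scatter). Compound 4 is therefore estimated at 45 nM, within a range from 15 nM to 130 nM.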

Compound 4, concentration for 50% growth inhibition: 255 nM
Compound 4: middle estimate off by 5.7-fold (0.75 log units), on the low side; the measured number lies above the stated range.
By their numbers in this assay, from the lowest: compound 2; then compound 3; then compounds 4 and 1 (each within the scatter of the next).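

In this assay, replacing 2,3-dihydroxypropyl with 1-(hydroxymethyl)propyl on the sulfur gives a 12-fold higher number from compound 2 to compound 4 (1.08 log units; beyond the scatter) even though the heavy-atom count stays the same, so this position responds strongly to a change that leaves the size of the group untouched. The new group also compares poorly with the amine-bearing chain, with a 4.6-fold higher number from compound 3 to compound 4 (0.66 log units; beyond the scatter) on the same sulfur, while the remaining comparison is a 1.5-fold lower number from compound 1 to compound 4 (0.18 log units; within the scatter) and gives no order between those two compounds. Nothing measured here accounts for the size of these steps.

Compound 4 loses a hydroxyl and gains an ethyl branch in a single change, so the compounds shown cannot separate these two effects. As far as these compounds go, how a 2-hydroxyethyl group on the same sulfur would compare remains open.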